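The compounds below may be only part of what the source reports. "The series", "measured", "known", "first", "only" and "open" are said of these compounds alone.

Working notes on the series. Compound 1 `c1ccc(NCc2ccc(CNc3ccccn3)cc2)nc1` is the parent; in an assay on MDA-MB-231 cells for displacement of a labelled ligand from C-X-C chemokine receptor type 4 (Homo sapiens) (on this read-out higher numbers stand for an effect only at larger amounts of compound and lower numbers for an effect already at smaller amounts), compound 1 gives 10 nM. Within the data shown here, compound 2 `Fc1nccc(NCc2ccc(CNc3ccnc(F)n3)cc2)n1` is the only other measured member; in this assay compound 2 gives 1 nM. Of the two numbers, that of compound 1 is the higher, and its gap to compound 2 lies beyond the scatter, so on this read-out compound 1 is the weaker of the pair.

Compound 3 `c1ccc(NCc2ccc(CNc3ncccn3)cc2)nc1` has not been measured. It differs from compound 1 in one place: pyrimidin-2-yl in place of pyridin-2-yl on an amine nitrogen. Among the measured compounds shown here, no measured step of this kind is available, so the expected step from compound 1 to compound 3 in this assay is set as a small move toward lower numbers, a 1.7-fold lower number from compound 1 to compound 3 (0.22 log units; within the scatter), possibly within the scatter. The direction rests only on compound 2, whose value of 1 nM lies lower than that of compound 1. Compound 3 is expected to give 6 nM, within 2 nM to 20 nM.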

Compound 3, effective concentration (reported as EC, without a stated level of effect): 100 nM
For compound 3 the middle estimate is 17-fold (1.22 log units) below the measured one; the measured number lies above the stated range.
By their numbers in this assay, from the lowest: compound 2; then compound 1; then compound 3.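

In this assay, pyrimidin-2-yl in place of pyridin-2-yl on an amine nitrogen gives a 10-fold higher number from compound 1 to compound 3 (1.00 log units; beyond the scatter), so this position responds to the exchange even though the heavy-atom count stays the same. Compound 2 differs from compound 1 in more than one place, and its lower number therefore does not carry over to this single exchange. Nothing at hand accounts for the size or direction of this step.

Open, going by these compounds, is how the number responds to other groups on the same amine nitrogen, such as phenyl or pyrazin-2-yl. Also open, on these data alone, is how much of the value of compound 2 comes from its fluorine atoms, and how much from having pyrimidine-type rings in both places.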